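A few compounds are considered here, and "the series" means these few. Any claim that something is new, unique, unknown or untested is made for them only; others in the source may bear on it.

Compound 1 `C=C1CC[C@H]2[C@@](C)(CCC(=O)N[C@@]2(C)COC(=O)[C@H](N)CC(C)C)[C@@H]1/C=C/C1=CCOC1=O`: > 50000 nM
Compound 2 `C=C1CC[C@H]2[C@@](C)(CC[C@@H](OC(=O)c3cccnc3)[C@@]2(C)NC=O)[C@@H]1/C=C/C1=CCOC1=O`: > 50000 nM
Compound 3 `C=C1CC[C@H]2[C@@](C)(CC[C@@H](OC(=O)[C@H](N)CC(C)C)[C@@]2(C)NC=O)[C@@H]1/C=C/C1=CCOC1=O`: > 50000 nM

These values come from a functional assay on RAW264.7 cells (Mus musculus) for inhibition, read by Griess assay, with stated times of 3 h and 24 h; on this read-out lower numbers stand for stronger inhibition and higher numbers for weaker inhibition. In this assay compound 3 gives > 50000 nM, which is a limit and not a number. The picture so far is the limit of > 50000 nM in this assay, at which 3 of the 3 values shown sit.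

Compound 4 `C=C1CC[C@H]2[C@@](C)(CC[C@@H](OC(=O)CN)[C@@]2(C)NC=O)[C@@H]1/C=C/C1=CCOC1=O` differs from compound 3 by one change, (hydrogen in place of isobutyl on a saturated chain carbon bound to an amine nitrogen and a carbonyl carbon), which turns 1-amino-3-methylbutyl into aminomethyl. Within the data shown here, the one measured step that bears on this, also a change on a carbonyl carbon, is a step that the two limits leave unreadable from compound 2 to compound 3, so it offers no size to carry over. The expected result, with no direction favoured, is a step that the limit leaves unreadable from compound 3 to compound 4. For compound 4 the estimate is 60000 nM, with an expected range of 25000 nM to 120000 nM.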

Compound 4, half-maximal inhibitory concentration: > 50000 nM
Compound 4: a limit, no number; the forecaster's own chance of this, stated with the estimate: 80%; the middle value is on the limit's open side.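

In this assay compound 4 gives > 50000 nM, a limit and not a number, so the steps linking compound 2, compound 3 and compound 4 cannot be read. Still open is how the side groups on these compounds alter inhibition, with every result at the same limit: the limit of > 50000 nM in this assay, at which 4 of the 4 values shown sit.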